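A few compounds are considered here, and "the series" means these few. Any claim that something is new, unique, unknown or untested is made for them only; others in the source may bear on it.

Of the compounds shown here, two of the shared core have been measured in an assay on cells for inhibition of HSP60/HSP10 (Homo sapiens), with a stated time of 60 min; a higher number here means a weaker inhibitor, a lower number a stronger inhibitor. Compound 1, with the structure `O=S(=O)(Nc1ccc(-c2nc3ccccc3o2)cc1)c1cccc(F)c1`, gives 71000 nM. Compound 2, with the structure `CCc1ccc(S(=O)(=O)Nc2ccc(-c3nc4ccccc4o3)cc2)cc1`, reaches only the limit of the assay, reported as > 100000 nM, so no number is known for it; it stands at the limit of > 100000 nM in this assay, at which 1 of the 2 values shown sits. The step of an at least 1.4-fold higher number from compound 1 to compound 2 (0.14 log units; that floor lies within the scatter) is therefore known only as a floor, and that floor lies within the scatter of repeated measurements.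

Compound 3, with the structure `O=S(=O)(Nc1ccc(-c2nc3ccccc3o2)cc1)c1ccc(Cl)cc1`, has not been measured. Its difference from compound 2 is chloro in place of ethyl on an aromatic carbon.

Within the data shown here, the only measured step that bears on this change is the one from compound 1 to compound 2, and it shows at most a small movement, with compound 2 sitting at the limit. Both measured values are weak, so compound 3 is expected to stay in that region, with the estimated step of a number no higher from compound 2 to compound 3 (the limit leaves the size open) small or none beyond the scatter. Compound 3 is accordingly estimated at 100000 nM, with a range from 30000 nM to 300000 nM in this assay, and a real chance that only a limit is reported again.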

Compound 3, half-maximal inhibitory concentration: 61000 nM
Beside the measured number, compound 3's estimate is 1.6-fold (0.21 log units) above it, and the stated range covers the measured number.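

In this assay, the change from ethyl to chloro, para to a large group, now has a measured number on the chloro side, and the step reads an at least 1.6-fold lower number from compound 2 to compound 3 (0.21 log units; that floor lies within the scatter). Compound 2 carries a limit and not a number, so this step is known only as a floor, and its true size cannot be read: the limit of > 100000 nM in this assay, at which 1 of the 3 values shown sits. Set against the other compound with a halogen on this ring, the reading is a 1.2-fold lower number from compound 1 to compound 3 (0.07 log units; within the scatter), so 4-chlorophenyl and 3-fluorophenyl on the sulfonyl sulfur cannot be told apart here, and both give a measurable though weak number.

The compounds shown leave open whether any group on this ring can bring the number down well beyond the scatter, as all three stay in the same weak region. An amine, a carboxylic acid or a methoxy group in this place could answer that, as could a longer chain in place of ethyl, and nothing shown says how any of them would read.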